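Trading 4-chlorophenyl for trifluoromethyl in a weak growth inhibitor

A few compounds are considered here, and "the series" means these few. Any claim that something is new, unique, unknown or untested is made for them only; others in the source may bear on it.

Compound 1 `CC(=O)c1ccc(NC(=O)Cn2nc(-c3ccc(Cl)cc3)nc2N)cc1` gives 10.4%
Compound 2 `C/C(=N\O)c1ccc(NC(=O)Cn2nc(-c3ccc(Cl)cc3)nc2N)cc1` gives 13.3%

In a functional assay on HT-29 cells (Homo sapiens) for inhibition, read by sulforhodamine B assay, with a stated time of 48 h, tested at 10 uM (a higher number here means more inhibition of growth at the concentration tested, a lower number less inhibition of growth), compound 1 and compound 2 lie within the scatter of each other, and neither shows much inhibition of growth. Compound 3 `CC(=O)c1ccc(NC(=O)Cn2nc(C(F)(F)F)nc2N)cc1` keeps the core of compound 1 with a single change: trifluoromethyl in place of 4-chlorophenyl on an aromatic carbon. Among the measured compounds shown here, the only measured step, a number 2.9 percentage points higher from compound 1 to compound 2 (within the scatter), alters a different part of the molecule. For the measured compounds named here, it therefore says little about this swap, and no measured compound lacks the 4-chlorophenyl group. Compound 1 already stands at 10.4%, which leaves little room for a fall, while nothing measured points to a rise. The expected change is a number 1.4 percentage points lower from compound 1 to compound 3 (within the scatter), so no step beyond the scatter is anticipated. The estimate for compound 3 is 9%, within an expected range from 0% to 24%.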

Compound 3, percent growth inhibition at one concentration: 16%
Beside the measured number, compound 3's estimate is 7 percentage points below it; measured number inside the range.
By their numbers in this assay, from the lowest: compounds 1, 2 and 3 (each within the scatter of the next).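

In this assay, a change on an aromatic carbon of a five-membered aromatic ring gives a number 5.6 percentage points higher from compound 1 to compound 3 (within the scatter) when trifluoromethyl replaces 4-chlorophenyl. Among the compounds shown here, the earlier step altered another part of the molecule, so this is the first reading at this position: losing the whole six-membered aromatic ring, and with it the chlorine, leaves a number that cannot be told apart from that of compound 1. No evidence bears on this result.

From the compounds shown here alone, whether a carboxylic acid, an amine or a plain phenyl at this position would move the number beyond the scatter remains open. So does whether trifluoromethyl would give a similar reading when carried on compound 2 rather than on compound 1.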